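The source may hold more compounds than are shown below. What is called first, only, known or untested is meant among the compounds shown, and "the series" means these compounds.

Measured compounds:
compound 1 `COc1ccc(/C=C/C(=O)OC[C@H]2O[C@@H](O[C@@H]3OC=C[C@@]4(O)[C@H](O)C[C@](C)(O)[C@@H]34)[C@H](O)[C@@H](O)[C@@H]2O)cc1` gives 60.9%
compound 2 `COc1ccc(/C=C\C(=O)O[C@@]2(C)C[C@@H](O)[C@]3(O)C=CO[C@@H](O[C@@H]4O[C@H](CO)[C@@H](O)[C@H](O)[C@H]4O)[C@@H]32)cc1` gives 48.2%
compound 3 `N#Cc1cc2c(cc1[N+](=O)[O-])=NC(=O)C(=O)N=2` gives 47.3%

All three numbers come from a functional assay (Cortical neurone cells, Rattus norvegicus, strain Sprague-Dawley), read by spectrophotometry and LDH release, with stated times of 1 h and 24 h, tested at 1 uM; a lower number here means a weaker effect, a higher number a stronger effect of the compound at the concentration tested. Among them, compound 2 stands second highest. Its nearest neighbour is compound 3, whose number lies within the usual scatter, so the two cannot be told apart. Compound 1 lies furthest away, with a number higher by a gap beyond the scatter.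

Compound 4 `COc1ccc(/C=C/C(=O)O[C@@]2(C)C[C@@H](O)[C@]3(O)C=CO[C@@H](O[C@@H]4O[C@H](CO)[C@@H](O)[C@H](O)[C@H]4O)[C@@H]32)cc1` has not yet been measured in this assay. It differs from compound 2 as follows: the two compounds have the same atoms and bonds and differ only in configuration as drawn: 1 of 11 stereo elements differ; a double bond is drawn Z in compound 2 and E in compound 4. Among the measured compounds shown here, no measured pair shows such a change, so there is no measured guide for its size. Compound 4 is expected to give about 52%, within 38% to 66%. The step this estimate means, a number 3.8 percentage points higher from compound 2 to compound 4 (within the scatter), is expected to stay within the scatter, with no clear direction.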

Compound 4, a percentage reported as activity, at one concentration (the size of the read-out at that concentration, not a potency): 61.8%
Compound 4: the middle estimate sits 9.8 percentage points below what was measured; the measured number falls inside the stated range.
By their numbers in this assay, from the lowest: compounds 3 and 2 (each within the scatter of the next); then compounds 1 and 4 (each within the scatter of the next).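

In this assay, turning the double bond from Z to E gives a number 13.6 percentage points higher from compound 2 to compound 4 (beyond the scatter), so configuration alone, with no atom added or removed, can move this read-out. The step can be assigned to that one double bond because nothing else separates the pair: the fact that compounds 2 and 4 differ only in the configuration as drawn. Among the compounds shown here, it is the first measured size for such a change, though it rests on a single pair at one concentration.

As far as these compounds go, whether the same switch acts alike on other compounds stays open. So does what an amine or a carboxylic acid in place of the ester would do.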